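The compounds below may be only part of what the source reports. "The series", "measured", "known", "first", "only" and "open" are said of these compounds alone.

The measured compounds and their results:

compound 1, `Cn1nc(CN2CCCC2)nc1-c1ccc2ccsc2c1`, gives > 1000 nM in an assay on membranes from Jurkat cells for displacement of a labelled ligand from Sigma intracellular receptor 2 (Homo sapiens), read by scintillation counting, with a stated time of 1 h (on this read-out higher numbers stand for weaker inhibition and lower numbers for stronger inhibition), which is a limit of the assay rather than a number.
compound 2, `Cn1nc(CN2CCCC2)nc1-c1ccc(Cl)cc1`, gives > 1000 nM in this assay, again a limit of the assay.
compound 3, `Cn1nc(CN2CCCC2)nc1-c1ccc(Cl)c(Cl)c1`, gives > 1000 nM in this assay, also a limit of the assay.

Compound 2 and compound 3 share a core and differ in one place: chloro in place of hydrogen on an aromatic carbon. The step from one to the other, a step that the two limits leave unreadable from compound 2 to compound 3, cannot be sized, because of the limit of > 1000 nM in this assay, at which 3 of the 3 values shown sit. How the core of compound 1 differs from the core of compound 2 is not broken down here.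

Compound 4, `Cn1nc(CN2CCCC2)nc1-c1ccc2cc(Cl)sc2c1`, has not yet been measured. It differs from compound 1 by chloro in place of hydrogen on an aromatic carbon. Going by the values given here, this is the same kind of change as the one between compound 2 and compound 3, but not the same: there the chloro entered on a six-membered aromatic ring of carbon only, ortho to a chloro group and meta to a large group; here it enters on a five-membered aromatic ring with one sulfur, part of a fused system of two rings, next to the ring sulfur.

Because compound 1 sits at a limit, > 1000 nM, and the comparable change left compound 3 at a limit as well, the step from compound 1 to compound 4 in this assay is expected to be a step that the limit leaves unreadable from compound 1 to compound 4. Compound 4 is therefore expected to give about 3000 nM, most likely between 800 nM and 20000 nM, and a further limit rather than a number is the likeliest outcome.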

Compound 4, inhibition constant: 1000 nM
Compound 4: middle estimate off by 3.0-fold (0.48 log units), on the high side; measured number inside the range.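

In this assay, putting chloro in place of hydrogen on the core of compound 1 gives a number no higher from compound 1 to compound 4 (the limit leaves the size open). Compound 4 gives 1000 nM, which is a measured number, and it is the only such number among the compounds shown. On this core the change does not leave the result at the limit of the assay. This does not show how large the step is, or whether chloro acts in the same way on the two cores, since the step from compound 2 to compound 3 cannot be read either and the change sits on a different kind of ring in each pair, and neither step can be sized because of this: the limit of > 1000 nM in this assay, at which 3 of the 4 values shown sit.

The compounds shown leave open what a group other than chloro, such as a methyl, a methoxy or an amine, would give on the five-membered aromatic ring, next to the ring sulfur. They also leave open whether a carboxylic acid or a longer chain at that place would give a clearly lower number than compound 4 or would return the result to a limit of the assay.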